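The compounds below may be only part of what the source reports. "The series", "measured", "known", "first", "only" and "open" are said of these compounds alone.

Compound 1, `CC(=O)O[C@@H]1C=CC(=O)O[C@@H]1[C@@H](COC(=O)c1ccc(Cl)cc1)OC(C)=O`: in an ADME assay on MRC5 cells (Homo sapiens) for cytotoxicity, read by MTT assay, with a stated time of 6 days (a higher number here means a weaker inhibitor, a lower number a stronger inhibitor), compound 1 gives > 100000 nM, a limit of the assay.
Compound 2, `COc1ccc(/C=C/C(=O)OC[C@@H](OC(C)=O)[C@H]2OC(=O)C=C[C@H]2OC(C)=O)cc1`: in this assay compound 2 gives 78000 nM.
Compound 3, `CC(=O)O[C@@H]1C=CC(=O)O[C@@H]1[C@@H](COC(=O)/C=C/c1ccc(F)cc1)OC(C)=O`: in this assay compound 3 gives > 100000 nM, a limit of the assay.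

Compound 3 thus stands at the weak end of the measured set, with only a limit and no number, as does compound 1 (the limit of > 100000 nM in this assay, at which 2 of the 3 values shown sit). Compound 4, `CC(=O)O[C@@H]1C=CC(=O)O[C@@H]1[C@@H](COC(=O)/C=C/c1ccc([N+](=O)[O-])cc1)OC(C)=O`, differs from compound 3 by nitro in place of fluoro on an aromatic carbon. The closest measured step is an at least 1.2-fold higher number from compound 2 to compound 3 (0.10 log units; that floor lies within the scatter), a change at the same aromatic carbon; the others are an at least 1.2-fold lower number from compound 1 to compound 2 (0.10 log units; that floor lies within the scatter) and a step that the two limits leave unreadable from compound 1 to compound 3. None of them is readable as a change beyond the scatter. In this assay compound 4 is therefore expected to give about 120000 nM, between 60000 nM and 300000 nM. The expected step is a step that the limit leaves unreadable from compound 3 to compound 4.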

Compound 4, half-maximal inhibitory concentration: > 100000 nM
Compound 4: a limit, no number; the forecaster's own chance of this, stated with the estimate: 70%; the middle value lies beyond the limit too.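

With nitro on this aromatic carbon, compound 4 also gives only a limit in this assay, not a number: the limit of > 100000 nM in this assay, at which 3 of the 4 values shown sit. The step from fluoro to nitro cannot be read, as neither end is a number. Nitro in place of methoxy gives an at least 1.2-fold higher number from compound 2 to compound 4 (0.10 log units; that floor lies within the scatter), so this third group on the same carbon shows no change beyond the scatter.

On these data alone, whether compound 3 and compound 4 truly differ stays open. So does whether an amine or a carboxylic acid on this aromatic carbon would give a clear step.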